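This account rests on a few compounds, and the source may have more. Where it says the series, first, only, none or still open, it means among the compounds named here.

Working notes on the series in a functional assay on the whole organism (strain CD1) for inhibition, with Mus musculus as the target, with stated times of 15 min and 20 min, at a dose of 10 mg/kg by the subcutaneous route; a lower number here means less inhibition, a higher number more inhibition at the dose given (going by the name of the read-out). Compound 2 `CCOC(=O)/C(C#N)=C/c1cc2ccccc2[nH]1` stands highest of the two numbers, giving 88.4%; compound 1 `N#C/C(=C\c1cc2ccccc2[nH]1)C(=O)O` gives 25.8%. For the measured compounds named here, the only measured step, a number 62.6 percentage points higher from compound 1 to compound 2 (beyond the scatter), is the one that bears on the next change, though it replaced a hydrogen rather than one alkyl group with another. Compound 3 `CC(C)(C)OC(=O)/C(C#N)=C/c1cc2ccccc2[nH]1` differs from compound 2 by tert-butyl in place of ethyl on an oxygen next to a carbonyl group. Since the oxygen already carries an alkyl group in compound 2, a step of similar size is not expected; a small drop or none beyond the scatter seems most likely. Compound 3 is therefore expected to give 75%, within 45% to 95%. The expected step is a number 13.4 percentage points lower from compound 2 to compound 3 (beyond the scatter).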

Compound 3, a percentage reported as inhibition, in the whole organism at one dose (the size of the read-out at that dose, not a potency): 51.3%
Compound 3: middle estimate off by 23.7 percentage points, on the high side; the measured number falls inside the stated range.
By their numbers in this assay, from the lowest: compound 1; then compound 3; then compound 2.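

In this assay, the identity of the alkyl group at this position matters, not only its presence: tert-butyl in place of ethyl gives a number 37.1 percentage points lower from compound 2 to compound 3 (beyond the scatter) on this one change. Tert-butyl still retains part of the gain over hydrogen, with a number 25.5 percentage points higher from compound 1 to compound 3 (beyond the scatter) at the same position. Nothing available explains either step. Going by these compounds, how methyl or a longer chain such as n-butyl on this oxygen would read remains open, as does the effect of an amine in place of ethoxy.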